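The source may report more compounds than this note shows. Statements on the series, on what has been measured and on what is new or still open speak of the compounds shown alone.

Compound 3 `O=c1cc(-c2ccccc2)oc2ccc(OCCCCCCN3CCCC(O)C3)cc12` stands second highest of the three numbers in an assay on isolated protein (Cavia porcellus) with Sigma non-opioid intracellular receptor 1 (Homo sapiens) as the target, read by radioligand binding; a lower number here means a stronger inhibitor, a higher number a weaker inhibitor: compound 3 gives 77 nM. Its nearest neighbour is compound 2 `O=c1cc(-c2ccccc2)oc2ccc(OCCCCCCN3CCCCC3)cc12`, where compound 2 gives 54 nM, and the step of a 1.4-fold higher number from compound 2 to compound 3 (0.15 log units; within the scatter) lies within the scatter. Compound 1 `CN(C)CCCCCCOc1ccc2oc(-c3ccccc3)cc(=O)c2c1` is the furthest away, and compound 1 gives 335 nM.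

Compound 4 `CN(CCCCCCOc1ccc2oc(-c3ccccc3)cc(=O)c2c1)Cc1ccccc1` arises through (benzyl(methyl)amino in place of 3-hydroxypiperidin-1-yl on a saturated chain carbon, six bonds along the chain from an oxygen on an aromatic ring). Within the data shown here, no measured step exchanges the amine for benzyl(methyl)amino, so the evidence is indirect. Two steps swap the amine at that place: a 6.2-fold lower number from compound 1 to compound 2 (0.79 log units; beyond the scatter) and a 4.4-fold lower number from compound 1 to compound 3 (0.64 log units; beyond the scatter), both modest and both toward lower numbers as a ring amine replaced dimethylamino, while a 1.4-fold higher number from compound 2 to compound 3 (0.15 log units; within the scatter) showed that hydroxy on the ring changed little. The amine thus governs a modest span among these compounds, and benzyl(methyl)amino is expected to behave more like piperidin-1-yl than like dimethylamino. For compound 4 in this assay a step of a 1.5-fold lower number from compound 3 to compound 4 (0.19 log units; within the scatter) is expected, giving an estimated 50 nM with a range from 15 nM to 170 nM.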

Compound 4, half-maximal inhibitory concentration: 75 nM
Beside the measured number, compound 4's estimate is 1.5-fold (0.18 log units) below it; measured number inside the range.
By their numbers in this assay, from the lowest: compounds 2, 4 and 3 (each within the scatter of the next); then compound 1.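

In this assay, a 1.0-fold lower number from compound 3 to compound 4 (0.01 log units; within the scatter) and a 1.4-fold higher number from compound 2 to compound 4 (0.14 log units; within the scatter) both stay within the scatter, so at this place, on a saturated chain carbon six bonds along the chain from an oxygen on an aromatic ring, benzyl(methyl)amino cannot be told apart from either piperidine-type amine. The earlier compounds shown here showed a difference from dimethylamino only for amines with the nitrogen in a saturated ring, whereas a 4.5-fold lower number from compound 1 to compound 4 (0.65 log units; beyond the scatter) lies beyond the scatter and shows such a difference when phenyl replaces hydrogen on a saturated chain carbon bound to an amine nitrogen. No measurement shown accounts for these results.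

The compounds shown leave open whether morpholine or piperazine at the same place would fall with compound 2, compound 3 and compound 4 or with compound 1. They also leave open how a chloro or methoxy group on the benzyl ring, or a shorter chain, would change the number.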